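Chloro added on the trifluoromethylphenyl urea: series notes

The source may hold more compounds than are shown below. What is called first, only, known or untested is meant among the compounds shown, and "the series" means these compounds.

Measured compounds in a functional assay on MDA-MB-435 cells (Homo sapiens) for inhibition, read by sulforhodamine B assay, with a stated time of 48 h; on this read-out lower numbers stand for stronger inhibition and higher numbers for weaker inhibition:
compound 1, `O=C(Nc1cccc(-n2cc(-c3ccncc3)c(-c3ccc(Cl)c(O)c3)n2)c1)Nc1cccc(C(F)(F)F)c1`: 1490 nM
compound 2, `COc1cc(-c2nn(-c3cccc(NC(=O)c4cccc(C(F)(F)F)c4)c3)cc2-c2ccncc2)ccc1Cl`: 710 nM
compound 3, `COc1cc(-c2nn(-c3cccc(NC(=O)Nc4cccc(C(F)(F)F)c4)c3)cc2-c2ccncc2)ccc1Cl`: 870 nM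

Compound 3 lies within the scatter of both neighbours: the step of a 1.7-fold lower number from compound 1 to compound 3 (0.23 log units; within the scatter) and the step of a 1.2-fold higher number from compound 2 to compound 3 (0.09 log units; within the scatter) are each inside the usual spread of repeats, so the three numbers shown are not separated from one another.

Compound 4, `COc1cc(-c2nn(-c3cccc(NC(=O)Nc4ccc(Cl)c(C(F)(F)F)c4)c3)cc2-c2ccncc2)ccc1Cl`, carries the change (chloro in place of hydrogen on an aromatic carbon). Neither measured step bears on this position: the step from compound 1 to compound 3 concerns the methyl on the ring oxygen, and the step from compound 2 to compound 3 concerns the amide-to-urea linker. Both were within the scatter, and nothing in the data shows the trifluoromethylphenyl ring tolerating or rejecting an added chloro. The expectation for this assay is therefore a step of no size beyond the scatter, with the middle set on compound 3 and a wide range. For compound 4 the expected value is 800 nM, between 300 nM and 2200 nM, corresponding to an expected step of a 1.1-fold lower number from compound 3 to compound 4 (0.04 log units; within the scatter).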

Compound 4, half-maximal inhibitory concentration: 680 nM
Estimate against measurement, compound 4: 1.2-fold (0.07 log units) above, and the stated range covers the measured number.
By their numbers in this assay, from the lowest: compounds 4, 2, 3 and 1 (each within the scatter of the next, the first and the last beyond it).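

In this assay, chloro in place of hydrogen, on the aromatic carbon ortho to a trifluoromethyl group and para to a large group, gives a 1.3-fold lower number from compound 3 to compound 4 (0.11 log units; within the scatter). For the compounds shown here, this is the first reading at this position, and it shows that the added chlorine does not move the number beyond the scatter on the urea. The step of a 1.0-fold lower number from compound 2 to compound 4 (0.02 log units; within the scatter) likewise shows no separation when this chloro and the urea nitrogen enter together on the amide of compound 2, and no measurement available here accounts for either step.

Only chloro is shown at this position, so a methoxy, an amine or a carboxylic acid there remains open. Also open, going by these compounds, is whether the chloro alone reads the same on the amide linker, or on the free ring hydroxyl of compound 1.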